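The source may report more compounds than this note shows. Statements on the series, on what has been measured and on what is new or still open speak of the compounds shown alone.

Series notes. Compound 1 `COc1ccc(/C=C2\SC(=O)N(Cc3ccc(C)cc3)C2=O)cc1` and compound 2 `Cc1ccc(CN2C(=O)S/C(=C\c3ccccc3Cl)C2=O)cc1` share one core and differ only in the aryl group on the exocyclic double bond. In a functional assay on the whole organism (plasma) with Mus musculus as the target, with a stated time of 15 days, at a dose of 10 mg/kg by the oral route (a lower number here means a weaker effect, a higher number a stronger effect of the compound at the dose given), compound 1 gives 20.6%, and in this assay compound 2 gives 19.2%. Among the compounds with values here, the single measured step, a number 1.4 percentage points lower from compound 1 to compound 2 (within the scatter), is therefore flat. On the two numbers available compound 2 stands lowest, with compound 1 nearest at a distance that falls within the scatter, so no order between the two can be read.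

Compound 3 `Cc1ccc(CN2C(=O)S/C(=C\c3ccc(O)cc3)C2=O)cc1` is not yet measured in this assay. Its change from compound 2 is 4-hydroxyphenyl in place of 2-chlorophenyl on a double-bonded chain carbon bound to a double-bonded ring carbon. Within the data shown here, the only step that bears on this is a number 1.4 percentage points lower from compound 1 to compound 2 (within the scatter), which exchanged one aryl group for another at the same place and moved the read-out by an amount within the scatter. Among the measured compounds shown here, no step with a 4-hydroxyphenyl at this place has been measured, and compound 1 with its 4-methoxyphenyl is the closest point of reference. The expectation for compound 3 is thus a step of a number 1.8 percentage points higher from compound 2 to compound 3 (within the scatter), not beyond the scatter. Compound 3 is estimated at 21%, with a range from 8% to 36%.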

Compound 3, a percentage reported as activity, at one dose (the size of the read-out at that dose, not a potency): 19.9%
Compound 3: the middle estimate sits 1.1 percentage points above what was measured, within the range that was stated.
By their numbers in this assay, from the lowest: compounds 2, 3 and 1 (each within the scatter of the next).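

In this assay, 4-hydroxyphenyl on a double-bonded chain carbon bound to a double-bonded ring carbon brings 1 hydrogen-bond donor and 1 hydrogen-bond acceptor that 2-chlorophenyl lacks, yet the result is a number 0.7 percentage points higher from compound 2 to compound 3 (within the scatter) and the read-outs cannot be told apart. The new comparison, hydrogen in place of methyl on an oxygen on an aromatic ring, gives a number 0.7 percentage points lower from compound 1 to compound 3 (within the scatter), so 4-hydroxyphenyl and 4-methoxyphenyl cannot be told apart here either, and all three aryl groups now lie within the scatter of one another at this position. No supporting measurement is available to explain this lack of separation at this position.

On these data alone, whether any group at this place can produce a step beyond the scatter remains open, for example an amine or a carboxylic acid on the aromatic ring in place of the hydroxyl. As far as these compounds go, the three compounds also keep the rest of the shared core unchanged, so the effect of a change elsewhere on the core remains open too.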